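This account rests on a few compounds, and the source may have more. Where it says the series, first, only, none or still open, it means among the compounds named here.

Measured so far in a physicochemical assay for lipophilicity; a lower number here means a more polar compound, a higher number a more lipophilic compound:
compound 1 `CC(C)(C)C#Cc1cc(N(C(=O)[C@H]2CC[C@H](C)CC2)[C@H]2CC[C@@H](Oc3ccc(=O)[nH]n3)CC2)c(C(=O)O)s1` gives 1.8
compound 2 `CC(C)(C)C#Cc1cc(N(C(=O)[C@H]2CC[C@H](C)CC2)[C@H]2CC[C@H](OC3COC3)CC2)c(C(=O)O)s1` gives 2.6

Of these two, compound 2 stands higher, and its gap down to compound 1 lies beyond the scatter. Next in line is compound 3 `CC(C)(C)C#Cc1cc(N(C(=O)[C@H]2CC[C@H](C)CC2)[C@H]2CC[C@H](OC3CCOC3)CC2)c(C(=O)O)s1`, which carries oxolan-3-yl in place of oxetan-3-yl on an oxygen on a saturated carbon. The rest of the structure is unchanged.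

Among the compounds with values here, no measured pair shows this change, so the expectation rests on the structural difference alone and starts from compound 2 (2.6). A small upward move in this assay is expected, with no support yet from measured data. The estimated size is a number 0.30 log units higher from compound 2 to compound 3 (within the scatter) in that direction. The expected value for compound 3 is 2.9 (estimated range 2.5 to 3.3).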

Compound 3, distribution coefficient: 2.3
Estimate against measurement, compound 3: 0.60 log units above; measured number outside the range, below it.
By their numbers in this assay, from the lowest: compound 1; then compounds 3 and 2 (each within the scatter of the next).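

Within the series, the oxygen on a saturated carbon now has a first readable step: in this assay, oxolan-3-yl in place of oxetan-3-yl gives a number 0.30 log units lower from compound 2 to compound 3 (within the scatter). At this position, therefore, the four-membered and five-membered non-aromatic rings, each with 1 hetero atom, are not separated by this assay. Nothing measured here accounts for the size or direction of this step.

Still open, going by these compounds, is whether a different kind of group on the same oxygen, such as azetidin-3-yl with its ring amine, a carboxylic acid on a short chain, or a longer open alkyl chain, would stand beyond the scatter from compound 2. A single step also leaves open whether the same ring exchange would read alike on another part of the shared core.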